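This account rests on a few compounds, and the source may have more. Where it says the series, first, only, none or still open, it means among the compounds named here.

Measured so far in a functional assay on HepG2 cells (Homo sapiens) for antiproliferative activity, read by MTT assay, with a stated time of 72 h; a lower number here means a stronger inhibitor, a higher number a weaker inhibitor:

Compound 1 `O=C1COc2ccc(-c3cnc(Cl)c(NS(=O)(=O)c4ccc(F)cc4)c3)cc2N1c1ccccc1` gives 35700 nM.
Compound 2 `O=C1COc2ccc(-c3cnc(Cl)c(NS(=O)(=O)c4ccc(F)cc4)c3)cc2N1c1ccc(Cl)cc1` gives 33900 nM.
Compound 3 `Cc1ccc(N2C(=O)COc3ccc(-c4cnc(Cl)c(NS(=O)(=O)c5ccc(F)cc5)c4)cc32)cc1` gives 39600 nM.

Compound 3 has the highest of the three numbers, but the steps of a 1.1-fold higher number from compound 1 to compound 3 (0.05 log units; within the scatter) and a 1.2-fold higher number from compound 2 to compound 3 (0.07 log units; within the scatter) both lie within the scatter, as does a 1.1-fold lower number from compound 1 to compound 2 (0.02 log units; within the scatter), so the three stand level. Compound 4 `O=C1COc2ccc(-c3cnc(Cl)c(NS(=O)(=O)c4ccc(F)cc4)c3)cc2N1C1CC1` differs from compound 3 by cyclopropyl in place of 4-methylphenyl on an amide-type nitrogen in a ring. The measured steps only swap small groups on the 4-methylphenyl that now leaves; none replaces that ring itself, so they bear on this change only loosely and all were within the scatter. No step beyond the scatter is therefore expected, the expected step being a 1.0-fold lower number from compound 3 to compound 4 (0.02 log units; within the scatter). Compound 4 is estimated at 38000 nM, with a range from 14000 nM to 100000 nM.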

Compound 4, half-maximal inhibitory concentration: 8510 nM
Beside the measured number, compound 4's estimate is 4.5-fold (0.65 log units) above it, and the stated range ends above it.
By their numbers in this assay, from the lowest: compound 4; then compounds 2, 1 and 3 (each within the scatter of the next).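

Small swaps on the aromatic ring had moved nothing beyond the scatter, but replacing that whole ring on the amide-type nitrogen does move the number: cyclopropyl gives (a 4.7-fold lower number from compound 3 to compound 4 (0.67 log units; beyond the scatter)) and (a 4.0-fold lower number from compound 2 to compound 4 (0.60 log units; beyond the scatter)) and (a 4.2-fold lower number from compound 1 to compound 4 (0.62 log units; beyond the scatter)). This position therefore responds to the identity of the group as a whole, and compound 4 is the strongest of the four. Nothing available explains why. As far as these compounds go, whether the gain belongs to cyclopropyl alone stays open, since cyclobutyl, cyclohexyl or an open chain such as ethyl or isopropyl could behave differently.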